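This account rests on a few compounds, and the source may have more. Where it says the series, first, only, none or still open, it means among the compounds named here.

In an ADME assay on L132 cells (Homo sapiens) for cytotoxicity, read by MTT assay, with a stated time of 72 h (on this read-out lower numbers stand for stronger inhibition and higher numbers for weaker inhibition), compound 1 (`C=CCOc1cc(C2=C(c3cc(OC)c(OC)c(OC)c3)C(=O)C(O)C2)ccc1OC`) gives > 100 ug/mL, which is a limit of the assay and not a number. Compound 2 (`COc1ccc(C2=C(c3cc(OC)c(OC)c(OC)c3)C(=O)C(OC(C)=O)C2)cc1F`) gives < 1 ug/mL, which is also a limit. Of these two results, compound 1 therefore lies at the weak end, without an exact figure. Compound 3 (`COc1ccc(C2=C(c3cc(OC)c(OC)c(OC)c3)C(=O)C(O)C2)cc1OC(C)C`) has yet to be measured. It differs from compound 1 in one place: isopropyl in place of allyl on an oxygen on an aromatic ring. Within the data shown here, no measured pair shows this swap on its own, so the expectation rests on compound 1 and its > 100 ug/mL. The expected step of a number no higher from compound 1 to compound 3 (the limit leaves the size open) is none beyond the usual scatter, in either direction. Compound 3 is estimated at 100 ug/mL, with an expected range from 25 ug/mL to 300 ug/mL.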

Compound 3, half-maximal inhibitory concentration: > 100 ug/mL
Compound 3 gave a limit, no number (the forecaster's own chance of this, stated with the estimate: 55%); the middle value sits exactly at the limit.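

Compound 1 and compound 3 both end at a limit of this assay and not at a number, so no step between them can be read: the limit of > 100 ug/mL in this assay, at which 2 of the 3 values shown sit.

Going by these compounds, whether isopropyl in place of allyl on an oxygen on an aromatic ring changes the result at all, and by how much, stays open.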